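The compounds below may be only part of what the source reports. "The series", "measured", "known", "first", "only" and "open" are said of these compounds alone.

Measured so far in a functional assay on MCF7 cells (Homo sapiens) for cytotoxicity, read by CCK-8 assay, with a stated time of 72 h; on this read-out lower numbers stand for stronger inhibition and higher numbers for weaker inhibition:
- compound 1, `C=CCn1c(=O)/c(=C\c2cccc(Br)c2)[nH]c(=O)/c1=C\c1ccccc1OC`: 5400 nM
- compound 2, `C=CCn1c(=O)/c(=C\c2cccc(Br)c2)[nH]c(=O)/c1=C\c1cccc(Br)c1`: "not active" (no number reported)
- compound 3, `COc1ccccc1/C=c1/[nH]c(=O)/c(=C\c2cccc(Cl)c2Cl)[nH]c1=O`: "not active" (no number reported)

Going by the values given here, compound 1 is the only member of the set with a numerical half-maximal inhibitory concentration; in this assay compound 1 gives 5400 nM. Among the compounds with values here, compound 2 is reported in this assay as "not active" (no number reported) with no number attached, and compound 3 is likewise reported in this assay as "not active" (no number reported) without a number, so neither entry supports a computed step, and no pair of measured compounds differs in a single place.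

Compound 4, `C=CCn1c(=O)/c(=C\c2ccc(Cl)c(Cl)c2)[nH]c(=O)/c1=C\c1ccccc1OC`, has not yet been measured in this assay. Relative to compound 1 the change is 3,4-dichlorophenyl in place of 3-bromophenyl on a double-bonded chain carbon bound to an aromatic carbon. The remaining part of the molecule is unchanged.

Within the data shown here, with no measured step available between halogenated aryl variants, the expectation for this change is a step of no more than modest size, if anything toward weaker inhibition, given that compound 2 and compound 3 carry halogenated aryl groups and returned no number. Compound 4 is therefore expected to give about 7000 nM in this assay, within a range of 2500 nM to 25000 nM, which would amount to an estimated step of a 1.3-fold higher number from compound 1 to compound 4 (0.11 log units; within the scatter).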

Compound 4, half-maximal inhibitory concentration: "not active" (no number reported)
Compound 4 has no reported number here; there is nothing to compare the estimate with.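

In this assay, going by these compounds alone, compound 4 carries no number, so no step from compound 1 to compound 4 can be read. The compounds shown leave open how far 3,4-dichlorophenyl in place of 3-bromophenyl shifts the number. No supporting evidence bears on this result.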